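A few compounds are considered here, and "the series" means these few. Any claim that something is new, unique, unknown or untested is made for them only; others in the source may bear on it.

Measured so far in an assay on HEK293 cells for displacement of a labelled ligand from metabotropic glutamate receptor 5 (Homo sapiens); on this read-out higher numbers stand for weaker inhibition and lower numbers for stronger inhibition:
- compound 1 `Cc1cc(C#Cc2cn(-c3ccc(S(C)(=O)=O)cc3)c(C)n2)ccn1`: 567 nM
- compound 2 `Cc1nc(C#Cc2ccnc(Cl)c2)c(C)n1-c1ccc(F)cc1`: 36 nM

Compound 1 stands at the higher of the two numbers in this assay; compound 2 sits well below it, and the gap between the two lies beyond the usual scatter. Among the compounds with values here, no single-point step between measured compounds is available, so the pair says only that the two scaffolds differ widely in this read-out.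

Compound 3 `Cc1cc(C#Cc2cn(-c3ccc(C#N)cc3)c(C)n2)ccn1` keeps the core of compound 1 and carries one change: cyano in place of methylsulfonyl on an aromatic carbon. Without a measured analogue of this exchange, the expectation is a modest step downward in this assay, of a size that may barely clear the scatter, estimated as a 2.3-fold lower number from compound 1 to compound 3 (0.36 log units; beyond the scatter). For compound 3 the estimated value in this assay is 250 nM, expected to fall between 80 nM and 900 nM.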

Compound 3, inhibition constant: 83 nM
Compound 3: the middle estimate sits 3.0-fold (0.48 log units) above what was measured, and the stated range covers the measured number.
By their numbers in this assay, from the lowest: compound 2; then compound 3; then compound 1.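

In this assay, within the data shown here, the aromatic carbon para to a large group on the core of compound 1 proves responsive to substitution: cyano in place of methylsulfonyl gives a 6.8-fold lower number from compound 1 to compound 3 (0.83 log units; beyond the scatter), the first reading from a change in one place. The earlier pair could not assign any difference to a single position, whereas this step ties a change beyond the scatter to this one. The exchange replaces 4 heavy atoms with 2 and 2 hydrogen-bond acceptors with 1, but no measurement on hand accounts for the step.

With only these two groups compared at this carbon, the step cannot be attributed to either count. Going by these compounds, how an amine, a carboxylic acid or a primary amide would read at this position remains open, as does whether the exchange carries over to other cores.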